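Methoxy for fluoro at the aryl site in compound 4

The source may hold more compounds than are shown below. What is called first, only, known or untested is meant among the compounds shown, and "the series" means these compounds.

Among the measured compounds shown here, compound 3 `CC(=O)c1cc(-c2ccc(F)cc2)cc2cc(-c3ccc(F)cc3)[nH]c12` gives 20% in a functional assay on MCF7 cells (Homo sapiens) for cytotoxicity, read by MTT assay, with a stated time of 2 days, tested at 100 uM (on this read-out lower numbers stand for a stronger effect and higher numbers for a weaker effect at the one concentration tested), and stands lowest of the three numbers so far. The nearest is compound 1 `COc1ccc(-c2cc(C(C)=O)c3[nH]c(-c4ccccc4)cc3c2)cc1` with 30.8%, a difference beyond the scatter; the furthest is compound 2 `CC(=O)c1cc(-c2ccccc2)cc2cc(-c3ccc(F)cc3)[nH]c12` with 73.3%. For the measured compounds named here, the one single-point step within the set is a number 53.3 percentage points lower from compound 2 to compound 3 (beyond the scatter), a large change at the same aryl site that is now altered again.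

Compound 4 `COc1ccc(-c2cc(C(C)=O)c3[nH]c(-c4ccc(F)cc4)cc3c2)cc1` differs from compound 3 by methoxy in place of fluoro on an aromatic carbon. Going by the values given here, no measured step covers methoxy against fluoro directly. Compound 1 carries methoxy at this site, but also an unsubstituted phenyl on the other ring, so its value against compound 3 shows only that both methoxy and fluoro here sit well under compound 2, and no step is shown for that pair.

On this basis compound 4 is expected to stay near the low end, with the step of a number 6 percentage points higher from compound 3 to compound 4 (within the scatter) estimated as small and not clearly beyond the scatter, leaning slightly upward toward compound 1. The estimate for compound 4 in this assay is 26%, with a range from 12% to 45%.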

Compound 4, a percentage reported as activity, at one concentration (the size of the read-out at that concentration, not a potency): 14.8%
The estimate for compound 4 lay 11.2 percentage points above the measured number; the range from low to high includes it.
By their numbers in this assay, from the lowest: compounds 4 and 3 (each within the scatter of the next); then compound 1; then compound 2.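

In this assay, methoxy and fluoro cannot be told apart at this site on the shared core, with a number 5.2 percentage points lower from compound 3 to compound 4 (within the scatter). Measured against hydrogen at the same site, methoxy gives a number 58.5 percentage points lower from compound 2 to compound 4 (beyond the scatter), a large step like the one for fluoro, a number 53.3 percentage points lower from compound 2 to compound 3 (beyond the scatter), so two different groups on this ring now both go with a low number when compared with the unsubstituted phenyl of compound 2. The new pair also gives a second reading of fluoro in place of hydrogen, a number 16 percentage points lower from compound 1 to compound 4 (beyond the scatter), and this modest step shows that the size of the change does not carry over unchanged from one core to the other: the same change on two cores in this assay, a number 53.3 percentage points lower (beyond the scatter) from compound 2 to compound 3 and a number 16 percentage points lower (beyond the scatter) from compound 1 to compound 4, 37.3 percentage points apart, beyond the scatter of two such steps.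

The compounds shown leave open whether the low numbers hold for groups of another kind at this site, such as an amine or a carboxylic acid in place of the methoxy of compound 4. Among the compounds shown here, with only one concentration behind each number, they also give no potency for any compound.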